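From an Oxazole Sulfonamide Toward a Dichlorophenyl Analogue

The source may hold more compounds than are shown below. What is called first, only, known or untested is meant among the compounds shown, and "the series" means these compounds.

Three sulfonamides have been measured in a functional assay on DLD-1 cells (Homo sapiens) for antiproliferative activity, read by CellTiter-Glo, with a stated time of 72 h; on this read-out higher numbers stand for weaker inhibition and lower numbers for stronger inhibition. Compound 1 `Cc1cc(C)c(S(=O)(=O)N2CCN(C3CN4CCC3CC4)CC2)c(C)c1` gives 84 nM in this assay, and compound 3 `CC1CCN(C2CCN(S(=O)(=O)c3cccc(-c4ccc(Cl)cc4)c3)CC2)CC1` gives 15 nM. For compound 2 `Cc1noc(C)c1S(=O)(=O)N1CCC(N2CCC(C)CC2)CC1` this assay reports only a limit, > 5000 nM. For the measured compounds named here, compound 2 thus stands at the limit of > 5000 nM in this assay, at which 1 of the 3 values shown sits, and no measured step connects it to the other two compounds. Compound 4 `CC1CCN(C2CCN(S(=O)(=O)c3ccc(Cl)cc3Cl)CC2)CC1` differs from compound 2 in one place: 2,4-dichlorophenyl in place of 3,5-dimethyl-1,2-oxazol-4-yl on a sulfonyl sulfur. Going by the values given here, no step between measured compounds shows what this change does. Compound 3, which gives 15 nM, marks how strongly a sulfonamide in this series can inhibit. Compound 4 is expected to move toward that value, a step toward stronger inhibition beyond the usual scatter, an at least 50-fold lower number from compound 2 to compound 4 (1.69 log units; beyond the scatter). Compound 4 is therefore estimated at 100 nM, with a range from 20 nM to 600 nM.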

Compound 4, half-maximal inhibitory concentration: 1 nM
Beside the measured number, compound 4's estimate is 100-fold (2.00 log units) above it, outside the stated range (below it).
By their numbers in this assay, from the lowest: compound 4; then compound 3; then compound 1. At a limit, above all of these: compound 2.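

With 2,4-dichlorophenyl in place of 3,5-dimethyl-1,2-oxazol-4-yl on a sulfonyl sulfur, this assay shows an at least 5000-fold lower number from compound 2 to compound 4 (3.69 log units; beyond the scatter). For the compounds shown here, as the rest of the two structures is shared, this one place alone can carry a change of that size, which no earlier measured pair could show. The step rests on a limit for compound 2: the limit of > 5000 nM in this assay, at which 1 of the 4 values shown sits.

The compounds shown leave open whether both chlorines are needed. They also leave open how a plain phenyl, or a phenyl carrying an amine or a carboxylic acid, would compare on the sulfonyl sulfur.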